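Swapping a Chain Amide for Piperidine on a Shared Core

The source may report more compounds than this note shows. Statements on the series, on what has been measured and on what is new or still open speak of the compounds shown alone.

Compound 3 `COCCN(C)C(=O)[C@H](CC1CCCCC1)OC(=O)N[C@@H](C)CN1CC(C)(C)c2cc(F)ccc21` gives 172 nM in an assay on isolated protein for inhibition of cathepsin S (Homo sapiens) (on this read-out higher numbers stand for weaker inhibition and lower numbers for stronger inhibition), the second highest of the three numbers. Compound 1 `C[C@@H](CN1CCc2cc(F)ccc21)NC(=O)O[C@@H](CC1CCCCC1)C(=O)N1CCOCC1` gives 226 nM, a number within the scatter of compound 3, while compound 2 `O=C(N[C@@H](COCc1ccccc1)CN1CCc2cc(F)ccc21)O[C@@H](CC1CCCCC1)C(=O)N1CCOCC1` gives 8 nM. For the measured compounds named here, the one recorded step, a 28-fold lower number from compound 1 to compound 2 (1.45 log units; beyond the scatter), concerns benzyloxy on the chain and does not touch the amide end. Compound 4 `C[C@@H](CN1CC(C)(C)c2cc(F)ccc21)NC(=O)O[C@@H](CC1CCCCC1)C(=O)N1CCCCC1` differs from compound 3 by piperidin-1-yl in place of (2-methoxyethyl)(methyl)amino on a carbonyl carbon. Going by the values given here, no measured pair varies this amide alone; compounds 1 and 3 differ there and elsewhere, and their numbers lie within the scatter. The step expected from this change, a 1.0-fold lower number from compound 3 to compound 4 (0.01 log units; within the scatter), is therefore none beyond the scatter. Compound 4 is estimated at 170 nM, within a range from 70 nM to 420 nM.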

Compound 4, inhibition constant: 39 nM
Beside the measured number, compound 4's estimate is 4.4-fold (0.64 log units) above it; measured number below the stated range.
By their numbers in this assay, from the lowest: compound 2; then compound 4; then compounds 3 and 1 (each within the scatter of the next).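

In this assay, the amide end proved able to shift the number on its own: piperidin-1-yl in place of (2-methoxyethyl)(methyl)amino on a carbonyl carbon gave a 4.4-fold lower number from compound 3 to compound 4 (0.64 log units; beyond the scatter) with the rest of the structure unchanged. For the compounds shown here, earlier compounds had varied this end only together with other parts, so this is the first reading of the change alone. No supporting measurement bears on why the number fell.

Left open is whether the ring or the missing methoxy oxygen accounts for the step, and how a pyrrolidin-1-yl or diethylamino group would compare on that carbonyl carbon. Also open, on these data alone, is whether benzyloxy on the chain would add to this change in compound 4.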